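The compounds below may be only part of what the source reports. "The series", "measured", "known", "first", "only" and "open" are said of these compounds alone.

Compound 2 `O=S(=O)(Nc1ccc2oc(-c3ccccc3)nc2c1)c1ccc(Cl)c(C(F)(F)F)c1` carries a chloro group where compound 1 `O=S(=O)(Nc1ccc2oc(-c3ccccc3)nc2c1)c1ccc(F)c(C(F)(F)F)c1` carries a fluoro group. In an assay on cells for inhibition of HSP60/HSP10 (Homo sapiens), with a stated time of 60 min (on this read-out higher numbers stand for weaker inhibition and lower numbers for stronger inhibition), compound 1 gives 69000 nM. For compound 2 this assay reports only a limit, > 100000 nM. The step of an at least 1.4-fold higher number from compound 1 to compound 2 (0.16 log units; that floor lies within the scatter) can only be read as a floor, since one of its values sits at the limit of > 100000 nM in this assay, at which 1 of the 2 values shown sits. Compound 3 `O=[N+]([O-])c1cc(S(=O)(=O)Nc2ccc3oc(-c4ccccc4)nc3c2)ccc1Cl` differs from compound 2 by nitro in place of trifluoromethyl on an aromatic carbon. For the measured compounds named here, no measured step involves a nitro group, so the single measured step gives no guide to direction or size. Compound 3 is therefore expected to show a number no higher from compound 2 to compound 3 (the limit leaves the size open). Compound 3 is estimated at 100000 nM, with a range from 30000 nM to 300000 nM.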

Compound 3, half-maximal inhibitory concentration: 17000 nM
Compound 3: the middle estimate sits 5.9-fold (0.77 log units) above what was measured; measured number below the stated range.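

In this assay, the group at this position, ortho to a chloro group, can clearly shift the read-out: nitro in place of trifluoromethyl gives an at least 5.8-fold lower number from compound 2 to compound 3 (0.76 log units; beyond the scatter). This is the first step shown that is established as lying beyond the scatter, but its full size remains unknown: the limit of > 100000 nM in this assay, at which 1 of the 3 values shown sits.

On these data alone, it remains open whether nitro would give a similar shift with fluoro in place of chloro. How an amine, a nitrile or a carboxylic acid would read at this position is also open, and the compounds shown do not explain the shift.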